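Replacing the pyrazole of compound 1 with methylcarbamoyl

This account rests on a few compounds, and the source may have more. Where it says the series, first, only, none or still open, it means among the compounds named here.

Within the data shown here, compound 1 `Cc1n[nH]cc1-c1cccc2c1CCC2c1ncc[nH]1` is the one compound of the pair with a number in a functional assay on CHO cells for agonist activity at Alpha-1B adrenergic receptor (Homo sapiens), read by FLIPR and calcium flux; on this read-out higher numbers stand for an effect only at larger amounts of compound and lower numbers for an effect already at smaller amounts; in it compound 1 gives 902 nM. Compound 2 `Cn1nccc1-c1cccc2c1CCC2c1ncc[nH]1` reaches only a limit of the assay: in this assay compound 2 gives > 10000 nM. Among the measured compounds shown here, the single measured step, an at least 11-fold higher number from compound 1 to compound 2 (1.04 log units; beyond the scatter), shows that an exchange of the group on this aromatic carbon can move the number far, the second value sitting at the limit of > 10000 nM in this assay, at which 1 of the 2 values shown sits. Compound 3 `CNC(=O)c1cccc2c1CCC2c1ncc[nH]1` is not yet measured; it differs from compound 1 by methylcarbamoyl in place of 3-methyl-1H-pyrazol-4-yl on an aromatic carbon, the entering group bringing no ring. For the measured compounds named here, the only exchange measured at this place cost the activity, so a large step toward higher numbers is expected here as well: an 8.9-fold higher number from compound 1 to compound 3 (0.95 log units; beyond the scatter), with a fair chance that only a limit is reported. Compound 3 is estimated at 8000 nM, between 2000 nM and 30000 nM.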

Compound 3, half-maximal effective concentration: > 10000 nM
Compound 3: only a limit was reported; the forecaster's own chance of this, stated with the estimate: 50%; middle value at least 1.2-fold (0.09 log units) from the limit.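

In this assay, methylcarbamoyl in place of 3-methyl-1H-pyrazol-4-yl gives an at least 11-fold higher number from compound 1 to compound 3 (1.04 log units; beyond the scatter), so the loss at this aromatic carbon is no longer tied to a single exchange and also appears with an entering group that brings no ring. Of the compounds shown, only compound 1 gives a number, while the replacements with and without a ring both end at the same reading: the limit of > 10000 nM in this assay, at which 2 of the 3 values shown sit. The step from compound 2 to compound 3 cannot be read, since both values are limits.

On these data alone, how far compound 2 and compound 3 lie beyond that limit stays open, and so does any order between them. Also open, as far as these compounds go, is what a pyrazole without the methyl group, an amine or a carboxylic acid on this aromatic carbon would give.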